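Phenyl Added on the Carbon Bound to the Amine Nitrogen

The compounds below may be only part of what the source reports. "The series", "measured", "known", "first", "only" and "open" are said of these compounds alone.

Compound 1 `CN(O)/C=C\C(=O)c1ccc([N+](=O)[O-])cc1` was tested in a functional assay on cells (Homo sapiens) for inhibition (a lower number here means a stronger inhibitor, a higher number a weaker inhibitor), where compound 1 gives > 10000 nM, a limit of the assay rather than a number. Compound 2 `CN(O)/C=C\C(=O)c1ccc(Cl)cc1` carries chloro in place of nitro on an aromatic carbon, and in this assay compound 2 gives > 10000 nM, again a limit. The step that the two limits leave unreadable from compound 1 to compound 2 cannot be read because of the limit of > 10000 nM in this assay, at which 2 of the 2 values shown sit. Compound 3 `O=C(/C=C\N(O)Cc1ccccc1)c1ccc([N+](=O)[O-])cc1` differs from compound 1 by phenyl in place of hydrogen on a saturated chain carbon bound to an amine nitrogen. Among the measured compounds shown here, no measured step touches this kind of change: the only measured step alters the aromatic carbon and is itself unreadable, so it offers no guide to the size or direction of the step to be expected in this assay. Compound 3 is therefore expected to sit near 15000 nM, within a range from 3000 nM to 60000 nM. That estimate corresponds to a step that the limit leaves unreadable from compound 1 to compound 3, with a real chance that only a limit is returned once more.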

Compound 3, half-maximal inhibitory concentration: 1700 nM
Compound 3: the middle estimate sits 8.8-fold (0.95 log units) above what was measured, outside the stated range (below it).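

In this assay the change from methyl to benzyl, phenyl in place of hydrogen on a saturated chain carbon bound to an amine nitrogen, gives an at least 5.8-fold lower number from compound 1 to compound 3 (0.76 log units; beyond the scatter). Among the compounds shown here, this is the first readable step, as the step from nitro to chloro on the aromatic carbon cannot be read, and it shows that this place can shift the inhibition beyond the usual scatter. Going by these compounds, the full size of the step stays unknown because compound 1 gives only a limit, not a number: the limit of > 10000 nM in this assay, at which 2 of the 3 values shown sit.

A phenethyl chain or a cyclohexyl ring at this place would show whether the aromatic ring or simply a larger carbon group goes with the lower number. On these data alone, it also remains open whether benzyl gives a similar step when chloro replaces nitro on the aromatic carbon.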